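Cytotoxicity in liver cells along an amide series

A few compounds are considered here, and "the series" means these few. Any claim that something is new, unique, unknown or untested is made for them only; others in the source may bear on it.

Compound 1 `CS(=O)(=O)c1ccc(C(=O)NCCCC(=O)N2Cc3ccccc3C2)cc1[N+](=O)[O-]` and compound 2 `CS(=O)(=O)c1ccc(C(=O)NCCCC(=O)N2CCCCC2)cc1[N+](=O)[O-]` share one core and differ at a carbonyl carbon. In an ADME assay on HepG2 cells (Homo sapiens) for cytotoxicity, read by CellTiter-Glo and ATP content, with a stated time of 72 h (on this read-out higher numbers stand for an effect only at larger amounts of compound and lower numbers for an effect already at smaller amounts), compound 1 reaches only the limit of the assay, > 27000 nM. Compound 2 likewise reaches only a limit, > 27000 nM. The step that the two limits leave unreadable from compound 1 to compound 2 therefore cannot be read, since (the limit of > 27000 nM in this assay, at which 2 of the 2 values shown sit). Compound 3 `CN(Cc1ccccc1F)C(=O)CCCNC(=O)c1ccc(S(C)(=O)=O)c([N+](=O)[O-])c1` carries (2-fluorobenzyl)(methyl)amino in place of piperidin-1-yl on a carbonyl carbon. Among the compounds with values here, no measured step gives a size for this change, so the expectation for compound 3 in this assay is only that it again sits near the limit, an estimated 35000 nM (range 15000 nM to 90000 nM), with an expected step that the limit leaves unreadable from compound 2 to compound 3.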

Compound 3, half-maximal effective concentration: > 27000 nM
Compound 3 was reported as a limit; the forecaster's own chance of this, stated with the estimate: 80%; the middle value lies beyond the limit too.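

Compound 3, like compound 1 and compound 2, gives only a limit in this assay, so no step among these compounds can be read: the limit of > 27000 nM in this assay, at which 3 of the 3 values shown sit. From the compounds shown here alone, whether the group on the carbonyl carbon changes cytotoxicity at all stays open.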